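Replacing the fluorophenyl arm of compound 1 with an aminomethoxyphenyl

The compounds below may be only part of what the source reports. "The series", "measured", "known", "first", "only" and "open" are said of these compounds alone.

Within the data shown here, compound 1 `COc1cc(-c2ccnc3cc(-c4ccc(F)cc4)nn23)cc(OC)c1OC` stands highest of the two numbers so far: in a functional assay on A549 cells (Homo sapiens) for inhibition, read by CCK-8 assay, with a stated time of 48 h (a higher number here means a weaker inhibitor, a lower number a stronger inhibitor), compound 1 gives 3800 nM, while compound 2 `COc1cc(-c2ccnc3cc(-c4ccc(C)cc4)nn23)cc(OC)c1OC` gives 3 nM. Among the measured compounds shown here, the single known step, a 1300-fold lower number from compound 1 to compound 2 (3.10 log units; beyond the scatter), shows that the substituent on this phenyl arm can shift the result strongly. Compound 3 `COc1ccc(-c2cc3nccc(-c4cc(OC)c(OC)c(OC)c4)n3n2)cc1N` carries a different change at the same place, (3-amino-4-methoxyphenyl in place of 4-fluorophenyl on an aromatic carbon). For the measured compounds named here, no measured step covers this exact exchange, so the expectation rests only on compound 1 and the size of a 1300-fold lower number from compound 1 to compound 2 (3.10 log units; beyond the scatter). Compound 3 is therefore estimated at 400 nM (range 30 nM to 4000 nM), an expected step of a 9.5-fold lower number from compound 1 to compound 3 (0.98 log units; beyond the scatter).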

Compound 3, half-maximal inhibitory concentration: 138 nM
Estimate against measurement, compound 3: 2.9-fold (0.46 log units) above; the range from low to high includes it.
By their numbers in this assay, from the lowest: compound 2; then compound 3; then compound 1.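

In this assay, the 3-amino-4-methoxyphenyl arm gives a clearly lower number than 4-fluorophenyl (a 28-fold lower number from compound 1 to compound 3 (1.44 log units; beyond the scatter)) but a clearly higher one than 4-methylphenyl (a 46-fold higher number from compound 2 to compound 3 (1.66 log units; beyond the scatter)). This position therefore accepts an arm carrying both an amine and a methoxy group, yet this arm does not match the 4-methylphenyl arm of compound 2. No available evidence explains these differences. The compounds shown do not separate the contributions of the amine and the methoxy group. They also leave open how an arm with a hydroxyl group or a chlorine atom would compare.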